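The compounds below may be only part of what the source reports. "The series", "measured", "known", "first", "only" and "open" are said of these compounds alone.

In a functional assay on BT-549 cells (Homo sapiens) for cytotoxicity, read by MTT assay, with a stated time of 24 h (a lower number here means a stronger inhibitor, a higher number a weaker inhibitor), compound 1 `Cc1ccc2c(c1)OCC(Cc1ccc(O)cc1)C2=O`, which carries a hydroxy group, gives 28700 nM, and compound 3 `COc1ccc(CC2COc3ccccc3C2=O)c(OC)c1` gives 61900 nM. Compound 2 `O=C1c2ccccc2OCC1Cc1ccc(F)cc1` gives only a limit of the assay, > 200000 nM, and no number. Compound 4 `O=C1c2ccccc2OCC1Cc1ccc(O)cc1` differs from compound 2 by one change, (hydroxy in place of fluoro on an aromatic carbon), hydroxy in place of fluoro on an aromatic carbon. For the measured compounds named here, no measured pair isolates this change, so its size in this assay can only be expected. Going by the values given here, the one measured compound with a hydroxy group, compound 1 at 28700 nM, points to a lower number, beyond the scatter. The expected shift is an at least 4.4-fold lower number from compound 2 to compound 4 (0.64 log units; beyond the scatter). For compound 4 the estimated value is 45000 nM, with an expected range of 15000 nM to 130000 nM.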

Compound 4, half-maximal inhibitory concentration: 20100 nM
Compound 4: the middle estimate sits 2.2-fold (0.35 log units) above what was measured; the measured number falls inside the stated range.
By their numbers in this assay, from the lowest: compounds 4 and 1 (each within the scatter of the next); then compound 3. At a limit, above all of these: compound 2.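

In this assay, hydroxy in place of fluoro on an aromatic carbon, para to a large group, now has a measured size: an at least 9.9-fold lower number from compound 2 to compound 4 (0.99 log units; beyond the scatter). That size is a bound and not an exact figure, since compound 2 stands at a limit of the assay: the limit of > 200000 nM in this assay, at which 1 of the 4 values shown sits. Hydrogen in place of methyl on an aromatic carbon of the shared core leaves the reading within the scatter, with a 1.4-fold lower number from compound 1 to compound 4 (0.15 log units; within the scatter).

Going by these compounds, how an amine or a carboxylic acid in place of the hydroxy would read remains open.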